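The source may report more compounds than this note shows. Statements on the series, on what has been measured and on what is new or still open speak of the compounds shown alone.

Measured so far in a functional assay on CHO cells (Homo sapiens) for antiproliferative activity against CHO (Cricetulus griseus), read by sulforhodamine B assay, with a stated time of 48 h; a lower number here means a stronger inhibitor, a higher number a weaker inhibitor:
compound 1 `Cc1cc(C)cc(NS(=O)(=O)c2ccc(N3CCNC3=O)cc2)c1`: 210 nM
compound 2 `COc1cc(NS(=O)(=O)c2ccc(N3CCNC3=O)cc2)cc(OC)c1`: 330 nM

The numbers of compound 2 and compound 1 lie within the usual scatter of each other, so the two cannot be told apart. Compound 3 `COc1cccc(NS(=O)(=O)c2ccc(N3CCNC3=O)cc2)c1` differs from compound 2 by hydrogen in place of methoxy on an aromatic carbon. Within the data shown here, no measured pair shows this change on its own, so the expectation is tentative. The expected change is a 1.8-fold higher number from compound 2 to compound 3 (0.26 log units; within the scatter), a small move toward a weaker inhibitor in this assay, about the size of the scatter. For compound 3 the estimated value is 600 nM, with an expected range of 180 nM to 2000 nM.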

Compound 3, half-maximal inhibitory concentration: 330 nM
Compound 3: the middle estimate sits 1.8-fold (0.26 log units) above what was measured; the measured number falls inside the stated range.
By their numbers in this assay, from the lowest: compounds 1, 2 and 3 (each within the scatter of the next).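

In this assay, hydrogen in place of methoxy on an aromatic carbon gives no change at the digits printed from compound 2 to compound 3 (within the scatter), so this position tolerates losing one methoxy group without a visible effect. Putting 3-methoxyphenyl in place of 3,5-dimethylphenyl on the sulfonamide nitrogen gives a 1.6-fold higher number from compound 1 to compound 3 (0.20 log units; within the scatter), so this change cannot be told apart from no effect either. No outside evidence bears on these results. As far as these compounds go, whether an amine, a carboxylic acid or a longer chain at this place would move the number remains open. So does the effect of replacing the remaining methoxy with hydrogen.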